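Amide aryl exchange carried from one core to another

A few compounds are considered here, and "the series" means these few. Any claim that something is new, unique, unknown or untested is made for them only; others in the source may bear on it.

Compound 1, `O=C(Cn1nc(-c2ccccc2)c2ccccc2c1=O)Nc1ccc(Cl)cc1`, gives 33000 nM in a functional assay on MCF7 cells (Homo sapiens) for antiproliferative activity, read by sulforhodamine B assay, with a stated time of 72 h; on this read-out higher numbers stand for weaker inhibition and lower numbers for stronger inhibition.
Compound 2, `O=C(Cn1nc(-c2ccccc2)c2ccccc2c1=O)Nc1cccc(C(F)(F)F)c1`, gives 58000 nM in this assay.
Compound 3, `O=C(Cn1nc(Cc2ccccc2)c2ccccc2c1=O)Nc1ccc(Cl)cc1`, gives 13000 nM in this assay.

Compounds 1 and 2 share one core and differ only by 3-(trifluoromethyl)phenyl in place of 4-chlorophenyl on an amide-type nitrogen; this change made a 1.8-fold higher number from compound 1 to compound 2 (0.24 log units; within the scatter). Compound 3 carries a different core: benzyl in place of phenyl on an aromatic carbon. That change made a 2.5-fold lower number from compound 1 to compound 3 (0.40 log units; beyond the scatter). Compound 3 has the lowest number of the three, and its steps to compound 1 and to compound 2 are both beyond the scatter.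

Compound 4, `O=C(Cn1nc(Cc2ccccc2)c2ccccc2c1=O)Nc1cccc(C(F)(F)F)c1`, is not yet measured. It differs from compound 3 by 3-(trifluoromethyl)phenyl in place of 4-chlorophenyl on an amide-type nitrogen. This is the same change as that between compound 1 and compound 2, made at the same place, on an amide-type nitrogen whose other neighbour is the carbonyl carbon, here on the core of compound 3. Only this one earlier instance of the change is known, and no other pairs bear on it.

Among the compounds with values here, the step from compound 3 to compound 4 in this assay is expected to be a 1.8-fold higher number from compound 3 to compound 4 (0.25 log units; within the scatter), set beside the earlier 1.8-fold higher number from compound 1 to compound 2 (0.24 log units; within the scatter), because a 1.8-fold higher number from compound 1 to compound 2 (0.24 log units; within the scatter) is the sole precedent and lay within the scatter. The estimate for compound 4 in this assay is 23000 nM. The expected range for compound 4 runs from 9000 nM to 60000 nM.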

Compound 4, half-maximal inhibitory concentration: 3850 nM
Beside the measured number, compound 4's estimate is 6.0-fold (0.78 log units) above it; the measured number lies below the stated range.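

In this assay, 3-(trifluoromethyl)phenyl in place of 4-chlorophenyl on the amide-type nitrogen did not carry over from the core of compound 1 to the core of compound 3, where it gave a 3.4-fold lower number from compound 3 to compound 4 (0.53 log units; beyond the scatter), and the earlier step lay within the scatter while this one lies beyond it: the same change on two cores in this assay, a 1.8-fold higher number (0.24 log units; within the scatter) from compound 1 to compound 2 and a 3.4-fold lower number (0.53 log units; beyond the scatter) from compound 3 to compound 4, 5.9-fold (0.77 log units) apart, beyond the scatter of two such steps. Read along the other edge of the same four compounds, benzyl in place of phenyl on an aromatic carbon gave a 15-fold lower number from compound 2 to compound 4 (1.18 log units; beyond the scatter), a larger step with 3-(trifluoromethyl)phenyl on the amide than with 4-chlorophenyl: the same change on two cores in this assay, a 2.5-fold lower number (0.40 log units; beyond the scatter) from compound 1 to compound 3 and a 15-fold lower number (1.18 log units; beyond the scatter) from compound 2 to compound 4, 5.9-fold (0.77 log units) apart, beyond the scatter of two such steps. The two gaps rest on the same four values and so count as one observation of non-additivity, which shows that the outcome of the amide aryl exchange depends on the core in this set but gives no cause for it and no rule for other amide groups.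

Going by these compounds, whether the step on the core of compound 3 persists with other amide substituents, such as a pyridine ring or an aryl ring bearing an amine, remains open. Also open, on these data alone, is how a longer chain in place of benzyl, such as 2-phenylethyl, would behave with either amide aryl group.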